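This account rests on a few compounds, and the source may have more. Where it says the series, first, only, none or still open, it means among the compounds named here.

Measured compounds:
Compound 1, `Cc1nc(-c2nn(Cc3ccccc3F)c3ncccc23)oc1CO`: 900 nM
Compound 2, `CCCCc1cnc(-c2nn(Cc3ccccc3F)c3ncccc23)nc1N`: 218000 nM

In a functional assay (aorta) with Oryctolagus cuniculus as the target (on this read-out lower numbers stand for stronger inhibition and higher numbers for weaker inhibition), compound 1 gives 900 nM, while compound 2 gives 218000 nM. Among the compounds with values here, compound 2 thus stands at the higher of the two numbers, and the gap to compound 1 lies well beyond the usual scatter of this assay; the two compounds differ in several places at once, so their pair yields no single step.

The next compound, compound 3, `NCc1cnc(-c2nn(Cc3ccccc3F)c3ncccc23)nc1N`, is reached from compound 2 by one change: amino in place of propyl on a saturated chain carbon bound to an aromatic carbon. Within the data shown here, no measured pair shows this change, so its effect is not known from the data.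

Compound 3 is therefore expected to land near compound 2, with a modest step of a 2.7-fold lower number from compound 2 to compound 3 (0.44 log units; beyond the scatter) towards a lower number, but any direction within a wide band remains possible. The estimate for compound 3 in this assay is 80000 nM, with a range from 10000 nM to 400000 nM.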

Compound 3, half-maximal inhibitory concentration: 1400000 nM
Beside the measured number, compound 3's estimate is 18-fold (1.24 log units) below it; the measured number lies above the stated range.
By their numbers in this assay, from the lowest: compound 1; then compound 2; then compound 3.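

In this assay the swap of butyl for aminomethyl, read as amino in place of propyl on a saturated chain carbon bound to an aromatic carbon, gives a 6.4-fold higher number from compound 2 to compound 3 (0.81 log units; beyond the scatter) and so means weaker inhibition. Within the data shown here, this is the first single-place step, and it shows that the group at this place affects the read-out even though compound 2 already sat at a high number. It also shows that the shorter chain ending in an amino group does not recover inhibition here, but moves the number further up. Nothing at hand explains this rise.

As far as these compounds go, whether a hydroxymethyl group, a carboxylic acid or a longer chain at this place would bring the number down remains open. So does whether the same change would act alike on the core of compound 1.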